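Carbamoyl in Place of Hydroxymethyl: Expected Outcome

A few compounds are considered here, and "the series" means these few. Any claim that something is new, unique, unknown or untested is made for them only; others in the source may bear on it.

Compound 1 `O=C(CCCCCc1cccc(Br)c1)N1CCOC1=O` gives 430 nM in an assay on HEK293 cells for inhibition of N-acylethanolamine-hydrolyzing acid amidase (Rattus norvegicus), read by LC-MS, with a stated time of 30 min; on this read-out lower numbers stand for stronger inhibition and higher numbers for weaker inhibition.
Compound 2 `O=C(CCCCCc1cccc(O)c1)N1CCOC1=O` gives 8640 nM in this assay.
Compound 3 `O=C(CCCCCc1cccc(CO)c1)N1CCOC1=O` gives only a limit, > 20000 nM, in this assay.

Compound 3 therefore stands at the weak end of the three, at the limit (the limit of > 20000 nM in this assay, at which 1 of the 3 values shown sits), with no number of its own. Compound 4 `NC(=O)c1cccc(CCCCCC(=O)N2CCOC2=O)c1` differs from it by carbamoyl in place of hydroxymethyl on an aromatic carbon. Within the data shown here, the steps that bear on this are an at least 46-fold higher number from compound 1 to compound 3 (1.66 log units; beyond the scatter), a 20-fold higher number from compound 1 to compound 2 (1.30 log units; beyond the scatter) and an at least 2.3-fold higher number from compound 2 to compound 3 (0.36 log units; beyond the scatter): each exchange of bromo for a hydrogen-bond-donating group weakened inhibition in this assay, and hydroxymethyl weakened it further than hydroxy. Carbamoyl brings the same donor and acceptor count, so no recovery is expected; compound 4 is expected to remain at or beyond the limit, a step that the limit leaves unreadable from compound 3 to compound 4. The estimate for compound 4 is 22000 nM, within 8000 nM to 60000 nM.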

Compound 4, half-maximal inhibitory concentration: > 20000 nM
Compound 4: no number, only a limit (the forecaster's own chance of this, stated with the estimate: 60%); the middle value does not contradict the limit.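

Carbamoyl on this aromatic carbon joins hydroxymethyl at the weak end in this assay, and compound 4 gives only a limit: the limit of > 20000 nM in this assay, at which 2 of the 4 values shown sit. Carbamoyl in place of bromo gives an at least 46-fold higher number from compound 1 to compound 4 (1.66 log units; beyond the scatter), and carbamoyl in place of hydroxy gives an at least 2.3-fold higher number from compound 2 to compound 4 (0.36 log units; beyond the scatter), so compound 4, like compound 2 and compound 3, falls well short of compound 1. The step between compound 3 and compound 4 cannot be read, as both stand only at a limit.

The compounds shown leave open whether chloro, methyl or a carboxylic acid at this place would hold inhibition near that of compound 1.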